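Nitro for methyl on the amide aryl: expected effect

The source may report more compounds than this note shows. Statements on the series, on what has been measured and on what is new or still open speak of the compounds shown alone.

Three amides sharing one core have been tested: compound 1 `O=C(Nc1ccccc1[N+](=O)[O-])c1ccc(/N=N\c2c[nH]c3ccccc23)cc1`, compound 2 `Cc1ccccc1NC(=O)c1ccc(/N=N\c2c[nH]c3ccccc23)cc1` and compound 3 `Cc1cccc(NC(=O)c2ccc(/N=N\c3c[nH]c4ccccc34)cc2)c1`. In a functional assay on MCF7 cells (Homo sapiens) for inhibition, read by MTT assay, with a stated time of 72 h (on this read-out lower numbers stand for stronger inhibition and higher numbers for weaker inhibition), compound 1 gives 101000 nM, compound 2 gives 73400 nM and compound 3 gives 73400 nM. Compounds 2 and 3 differ by 3-methylphenyl in place of 2-methylphenyl on an amide-type nitrogen, and the step of no change at the digits printed from compound 2 to compound 3 (within the scatter). Compounds 2 and 1 differ by nitro in place of methyl on an aromatic carbon, giving a 1.4-fold higher number from compound 2 to compound 1 (0.14 log units; within the scatter). Compound 4 `O=C(Nc1cccc([N+](=O)[O-])c1)c1ccc(/N=N\c2c[nH]c3ccccc23)cc1` is not yet measured; it differs from compound 3 by nitro in place of methyl on an aromatic carbon. This is the same kind of change as from compound 2 to compound 1, but the nitro enters meta to a large group rather than ortho to a large group. Because a 1.4-fold higher number from compound 2 to compound 1 (0.14 log units; within the scatter) was small, the step of a 1.2-fold higher number from compound 3 to compound 4 (0.09 log units; within the scatter) is expected to be small too. Compound 4 is therefore estimated at 90000 nM, with a range from 40000 nM to 200000 nM.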

Compound 4, half-maximal inhibitory concentration: 51900 nM
Compound 4: the middle estimate sits 1.7-fold (0.24 log units) above what was measured; the range from low to high includes it.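

In this assay, nitro in place of methyl gives a 1.4-fold lower number from compound 3 to compound 4 (0.15 log units; within the scatter), and the other two steps to compound 4 are also within the scatter: a 1.4-fold lower number from compound 2 to compound 4 (0.15 log units; within the scatter) and a 1.9-fold lower number from compound 1 to compound 4 (0.29 log units; within the scatter). Set side by side, the same change on the two cores gives steps that cannot be told apart: the same change on two cores in this assay, a 1.4-fold higher number (0.14 log units; within the scatter) from compound 2 to compound 1 and a 1.4-fold lower number (0.15 log units; within the scatter) from compound 3 to compound 4, 1.9-fold (0.29 log units) apart, within the scatter of two such steps This shows that the change carries from one core to the other here only as a step too small to read; it does not show a shared direction or size, and two pairs cannot establish a rule for the series.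

The compounds shown carry only methyl or nitro on the amide phenyl ring. On these data alone, what an amine or a carboxylic acid would do there stays open, as does whether any such group would give a step beyond the scatter.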